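The compounds below may be only part of what the source reports. "The series", "measured", "known", "first", "only" and "open" are said of these compounds alone.

Working notes on the series. Three compounds have numbers in an ADME assay on cells (T-cell, Mus musculus, strain BALB/c) for cytotoxicity, read by MTT assay, with a stated time of 48 h; a higher number here means that more compound is tolerated, a lower number that less compound is tolerated. Compound 1 `COC(=O)c1c(Cl)cc(Cl)cc1OC(=O)COc1cc(O)c2c(=O)cc(-c3ccccc3)oc2c1` gives 345000 nM in this assay. Compound 2 `C=C(CCc1cc(O)c2c(=O)cc(-c3ccccc3)oc2c1)Cc1c(Br)cccc1C(=O)CC` gives 379000 nM in this assay. Compound 3 `COC(=O)c1ccc(Cl)cc1OC(=O)COc1cc(O)c2c(=O)cc(-c3ccccc3)oc2c1` gives 265000 nM in this assay. The three numbers lie within the scatter of one another, so compound 3 is not set apart from compound 1 or compound 2 on what has been measured.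

Among the measured compounds shown here, the one single-point step measured so far is a 1.3-fold lower number from compound 1 to compound 3 (0.11 log units; within the scatter), a change of hydrogen in place of chloro on an aromatic carbon that left the number where it was.

Compound 4 `COC(=O)c1ccccc1OC(=O)COc1cc(O)c2c(=O)cc(-c3ccccc3)oc2c1` differs from compound 3 by hydrogen in place of chloro on an aromatic carbon. For the measured compounds named here, this is the same kind of change as the one from compound 1 to compound 3, and that step stayed within the scatter; the step to compound 4 is therefore expected to stay within the scatter as well, with no direction assigned, which is the step of no change at the digits printed from compound 3 to compound 4 (within the scatter). Compound 4 is accordingly estimated at 265000 nM in this assay, with a range from 150000 nM to 470000 nM.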

Compound 4, half-maximal cytotoxic concentration: 265000 nM
For compound 4 middle estimate and measured number coincide at the digits printed; the range from low to high includes it.
By their numbers in this assay, from the lowest: compounds 3, 4, 1 and 2 (each within the scatter of the next).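

The step of no change at the digits printed from compound 3 to compound 4 (within the scatter) in this assay extends the earlier reading to a second place on this ring: the chloro para to the methoxycarbonyl group, in the 5-chloro-2-(methoxycarbonyl)phenyl group, can also give way to hydrogen with the number staying within the scatter. The step from compound 1 to compound 3 concerned the other chloro, so each of the two chloro-for-hydrogen changes has now been read on its own, and both are flat. No further data on these compounds bear on this result.

Going by these compounds, whether a group other than chloro or hydrogen at this carbon, such as an amine or a longer chain, would move the number remains open. So does the effect of a carboxylic acid in place of the methoxycarbonyl group.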